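A few compounds are considered here, and "the series" means these few. Any claim that something is new, unique, unknown or untested is made for them only; others in the source may bear on it.

Measured so far in a functional assay on NCI-H460 cells (Homo sapiens) for inhibition, read by sulforhodamine B assay, with a stated time of 48 h; on this read-out lower numbers stand for stronger inhibition of growth and higher numbers for weaker inhibition of growth:
compound 1 `COC(=O)c1sc2cc(C#Cc3ccc(OC)cc3)cnc2c1N`: 320 nM
compound 2 `COC(=O)c1sc2cc(C#Cc3ccc(N)cc3)cnc2c1N`: 8900 nM
compound 3 `COC(=O)c1sc2cc(C#Cc3cccnc3)cnc2c1N`: a limit of the assay, > 150000 nM

Compound 2 gives the highest of the two numbers; the step of a 28-fold higher number from compound 1 to compound 2 (1.44 log units; beyond the scatter) separates it from compound 1. For compound 3 only a limit is known, (the limit of > 150000 nM in this assay, at which 1 of the 3 values shown sits). Compound 4 `COC(=O)c1sc2cc(C#Cc3ccccc3N)cnc2c1N` differs from compound 2 by 2-aminophenyl in place of 4-aminophenyl on a triple-bonded carbon. For the measured compounds named here, no measured step moves a group around the ring; the two steps that change the group on the triple-bonded carbon, a 28-fold higher number from compound 1 to compound 2 (1.44 log units; beyond the scatter) and an at least 16-fold higher number from compound 2 to compound 3 (1.22 log units; beyond the scatter), were both large. A change beyond the scatter in this assay is therefore plausible, though its direction is uncertain. Compound 4 is estimated at 15000 nM, between 3000 nM and 80000 nM, an expected step of a 1.7-fold higher number from compound 2 to compound 4 (0.23 log units; within the scatter).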

Compound 4, concentration for 50% growth inhibition: 5700 nM
Compound 4: the middle estimate sits 2.6-fold (0.42 log units) above what was measured; the measured number falls inside the stated range.
By their numbers in this assay, from the lowest: compound 1; then compounds 4 and 2 (each within the scatter of the next). At a limit, above all of these: compound 3.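

In this assay, 2-aminophenyl in place of 4-aminophenyl on the triple-bonded carbon gives a 1.6-fold lower number from compound 2 to compound 4 (0.19 log units; within the scatter), so for the amino group, its place on the ring shows no effect beyond the scatter. Replacing the whole group still counts for far more: 2-aminophenyl in place of 4-methoxyphenyl gives an 18-fold higher number from compound 1 to compound 4 (1.25 log units; beyond the scatter), and in place of pyridin-3-yl it gives an at least 26-fold lower number from compound 3 to compound 4 (1.42 log units; beyond the scatter). That last step rests on a limit for compound 3: the limit of > 150000 nM in this assay, at which 1 of the 4 values shown sits.

The compounds shown leave open whether methoxy's place on the ring matters. They also leave open whether a hydroxyl or a carboxylic acid there would behave like the amino group.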